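The compounds below may be only part of what the source reports. "The series", "measured", "known", "first", "only" and "open" are said of these compounds alone.

Working notes on the benzoxazole amide series

The series starts from compound 1 `CN(C)CCN1CCN(CC(=O)Nc2ccc(-c3nc4cc(F)ccc4o3)cc2)CC1`, which in a functional assay on MCF7 cells (Homo sapiens) for cytotoxicity, read by MTT assay, with a stated time of 24 h (on this read-out higher numbers stand for weaker inhibition and lower numbers for stronger inhibition), gives 20800 nM. Among the compounds with values here, compound 2 `Cc1cc(-c2nc3cc(F)ccc3o2)ccc1NC(=O)CN1CCN(CCN(C)C)CC1` gives 10400 nM in this assay, and the single measured step, a 2.0-fold lower number from compound 1 to compound 2 (0.30 log units; within the scatter), is a methyl in place of hydrogen on an aromatic carbon of the anilide ring. Compound 3 `Cc1ccc2oc(-c3ccc(NC(=O)CN4CCN(CCCN(C)C)CC4)cc3)nc2c1` gives 19100 nM in this assay; on the numbers shown it is the second highest of the three, though its gaps to compound 1 and to compound 2 are both within the usual scatter.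

Compound 4 `Cc1ccc2oc(-c3ccc(NC(=O)CN4CCN(CCCN(C)C)CC4)c(C)c3)nc2c1` differs from compound 3 by methyl in place of hydrogen on an aromatic carbon. Within the data shown here, the one step that bears on this is the step from compound 1 to compound 2, which adds a methyl on an aromatic carbon of the same anilide ring and stays within the scatter. Nothing in the series suggests a step beyond the scatter here; a small move toward a lower number, if any, is all that the analogy supports.

Compound 4 is therefore expected at about 11000 nM in this assay, within 5000 nM to 25000 nM, which corresponds to an estimated step of a 1.7-fold lower number from compound 3 to compound 4 (0.24 log units; within the scatter).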

Compound 4, half-maximal inhibitory concentration: 19800 nM
For compound 4 the middle estimate is 1.8-fold (0.26 log units) below the measured one, within the range that was stated.
By their numbers in this assay, from the lowest: compounds 2, 3, 4 and 1 (each within the scatter of the next).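

In this assay, methyl in place of hydrogen on an aromatic carbon, ortho to a large group and meta to a 5-methyl-1,3-benzoxazol-2-yl group, gives a 1.0-fold higher number from compound 3 to compound 4 (0.02 log units; within the scatter). The earlier step, taken alone, left open whether this methyl might carry a small shift toward lower numbers; the second core gives no support for such a shift. Across the two cores, the change has no effect that can be separated from the scatter, and the two steps cannot be told apart: the same change on two cores in this assay, a 2.0-fold lower number (0.30 log units; within the scatter) from compound 1 to compound 2 and a 1.0-fold higher number (0.02 log units; within the scatter) from compound 3 to compound 4, 2.1-fold (0.32 log units) apart, within the scatter of two such steps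

From the compounds shown here alone, whether an ethyl group, a methoxy group or a chlorine atom in place of this methyl would give a step beyond the scatter remains open. Also open, going by these compounds, is whether a carboxylic acid or a primary amine on this ring would do so.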